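The source may hold more compounds than are shown below. What is called first, only, known or untested is meant among the compounds shown, and "the series" means these compounds.

Measured compounds:
compound 1 `O=C1/C(=C/c2ccc(Cl)cc2)Cc2ccccc21` — in a functional assay on L1210 cells (Mus musculus) for inhibition (a lower number here means a stronger inhibitor, a higher number a weaker inhibitor), compound 1 gives 54100 nM
compound 2 `O=C1/C(=C/c2ccc(Br)cc2)Cc2ccccc21` — in this assay compound 2 gives 64800 nM
compound 3 `O=C1/C(=C/c2ccc(Cl)cc2)CCCc2ccccc21` — in this assay compound 3 gives 51800 nM

The three values sit close together, and no two of them differ by more than the usual scatter, so no order among them is claimed. Compound 1 and compound 2 share one core and differ in one place: bromo in place of chloro on an aromatic carbon. This change gave a 1.2-fold higher number from compound 1 to compound 2 (0.08 log units; within the scatter). Compound 3 carries a different core; the difference between the two cores is not broken down here, and the two values show nothing beyond the scatter.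

Compound 4 `O=C1/C(=C/c2ccc(Br)cc2)CCCc2ccccc21` is not yet measured in this assay. It differs from compound 3 in one place: bromo in place of chloro on an aromatic carbon. Among the measured compounds shown here, both place lines read the same word for word, so this is the same change as the one from compound 1 to compound 2. Since that change gave a 1.2-fold higher number from compound 1 to compound 2 (0.08 log units; within the scatter), a step of about the same size is expected here, namely a 1.2-fold higher number from compound 3 to compound 4 (0.08 log units; within the scatter). Compound 4 is therefore estimated at 62000 nM, with a range of 35000 nM to 110000 nM.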

Compound 4, half-maximal inhibitory concentration: 50900 nM
For compound 4 the middle estimate is 1.2-fold (0.09 log units) above the measured one, within the range that was stated.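

In this assay, bromo in place of chloro on an aromatic carbon of the second core gives a 1.0-fold lower number from compound 3 to compound 4 (0.01 log units; within the scatter), and the two steps for this change can be set side by side: the same change on two cores in this assay, a 1.2-fold higher number (0.08 log units; within the scatter) from compound 1 to compound 2 and a 1.0-fold lower number (0.01 log units; within the scatter) from compound 3 to compound 4, 1.2-fold (0.09 log units) apart, within the scatter of two such steps. The change therefore reads the same on both cores shown, with no gap beyond the scatter between the two steps. Among the compounds shown here, this agreement is weak evidence of transfer: neither step lies beyond the scatter, so it shows only that the exchange of chloro for bromo leaves no readable step on either core, not that a step of real size would carry from one core to the other.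

The compounds shown hold only chloro and bromo at this place, on only two cores. Open, from the compounds shown here alone, are whether a methoxy group, an amine or a carboxylic acid on the same aromatic carbon would give a step beyond the scatter, and whether such a step would hold on both cores.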